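This account rests on a few compounds, and the source may have more. Where it says the series, first, only, none or still open, it means among the compounds named here.

Measured in a functional assay on cells (leukaemia cell line, Homo sapiens) for inhibition, read by sulforhodamine B assay, with a stated time of 48 h; a higher number here means a weaker inhibitor of growth, a lower number a stronger inhibitor of growth:
- compound 1 `O=S(=O)(Nc1cccc(Cl)c1)c1ccc(-c2cnc(C3CC3)o2)cc1`: 477 nM
- compound 2 `O=S(=O)(Nc1cc(Cl)ccc1Cl)c1ccc(-c2cnc(C3CC3)o2)cc1`: 1020 nM

Compound 2 holds the higher of the two numbers, so it is the weaker growth inhibitor of the pair. The next compound to consider is compound 3 `Cc1cc(F)cc(NS(=O)(=O)c2ccc(-c3cnc(C4CC4)o3)cc2)c1`, which carries 3-fluoro-5-methylphenyl in place of 2,5-dichlorophenyl on a sulfonamide nitrogen.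

For the measured compounds named here, only one measured step bears on this change: a 2.1-fold higher number from compound 1 to compound 2 (0.33 log units; beyond the scatter), modest in size, with a chloro in place of hydrogen on an aromatic carbon. Going by the values given here, it says little about fluoro or methyl, and no measured compound carries either group. The change removes both chlorines, so compound 3 is expected to move away from compound 2 and toward the level of compound 1 at 477 nM, without passing far beyond it. A small step toward a lower number is therefore expected in this assay, and a result close to compound 2 would not be surprising.

The expected step is a 1.9-fold lower number from compound 2 to compound 3 (0.27 log units; within the scatter). The estimated value for compound 3 is 550 nM, with an expected range of 230 nM to 1300 nM.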

Compound 3, concentration for 50% growth inhibition: 138 nM
Compound 3: the middle estimate sits 4.0-fold (0.60 log units) above what was measured, outside the stated range (below it).
By their numbers in this assay, from the lowest: compound 3; then compound 1; then compound 2.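

In this assay, for the compounds shown here, the aryl group on a sulfonamide nitrogen proves to be a stronger handle on growth inhibition than the single chloro step a 2.1-fold higher number from compound 1 to compound 2 (0.33 log units; beyond the scatter) suggested: 3-fluoro-5-methylphenyl in place of 2,5-dichlorophenyl gives a 7.4-fold lower number from compound 2 to compound 3 (0.87 log units; beyond the scatter), while the same group in place of 3-chlorophenyl gives a 3.5-fold lower number from compound 1 to compound 3 (0.54 log units; beyond the scatter). Loss of chlorine is therefore not simply a return to the level of compound 1, as compound 3 passes beyond it and holds the lowest number of the three, with both of its steps beyond the scatter. No measurement available here accounts for this gain, so the result stays an observation on these three compounds.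

Fluoro and methyl enter together in compound 3, so the share of each in the step cannot be separated, and a ring carrying only one of them would be needed to do so. Also open, going by these compounds, is how far this position extends to other groups on the aryl ring, such as methoxy, an amine or a carboxylic acid, or to a longer chain in place of the ring.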